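Aryl exchange on an aromatic nitrogen: compound 3 to compound 4

The source may report more compounds than this note shows. Statements on the series, on what has been measured and on what is new or still open speak of the compounds shown alone.

Measured so far:
- compound 1 `N#CC1=C(N)Oc2c(c3nc4ccccc4nc3c3ccccc23)C12C(=O)N(Cc1cnnn1-c1ccc(Cl)cc1)c1ccccc12`; in a functional assay on HepG2 cells (Homo sapiens) for antiproliferative activity, read by MTT assay, with a stated time of 48 h (on this read-out higher numbers stand for weaker inhibition and lower numbers for stronger inhibition), compound 1 gives > 50000 nM, which is a limit of the assay and not a number.
- compound 2 `N#CC1=C(N)Oc2c(c3nc4ccccc4nc3c3ccccc23)C12C(=O)N(Cc1cnnn1-c1cccc(Br)c1)c1ccccc12`; in this assay compound 2 gives > 50000 nM, again a limit.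
- compound 3 `N#CC1=C(N)Oc2c(N)cc3nc4ccccc4nc3c2C12C(=O)N(Cc1cnnn1-c1cccc(Br)c1)c1ccccc12`; in this assay compound 3 gives > 50000 nM, also a limit.

All three measured compounds sit at the limit of > 50000 nM in this assay, at which 3 of the 3 values shown sit, so no numbered inhibition has been recorded anywhere in the set. Among the measured compounds shown here, the only single-point change that can be compared, a step that the two limits leave unreadable from compound 1 to compound 2, runs between two limits and its size cannot be read. Compound 3 therefore stands where every other measured compound stands: at the limit, with no value of its own to rank it.

Compound 4 `Cc1cc(C)c(-n2nncc2CN2C(=O)C3(C(C#N)=C(N)Oc4c(N)cc5nc6ccccc6nc5c43)c3ccccc32)c(C)c1` differs from compound 3 by 2,4,6-trimethylphenyl in place of 3-bromophenyl on an aromatic nitrogen. For the measured compounds named here, no measured step bears on this change in a readable way; the one aryl-for-aryl exchange that exists in the set gave no readable size, and both of its ends were limits. With no evidence of a readable step in either direction, the expectation for compound 4 is that it remains at the limit, with the estimated step that the limit leaves unreadable from compound 3 to compound 4 being none beyond the scatter. Compound 4 is estimated at 60000 nM, within a range of 25000 nM to 150000 nM, most likely reported only as a limit.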

Compound 4, half-maximal inhibitory concentration: 48100 nM
Compound 4: the middle estimate sits 1.2-fold (0.10 log units) above what was measured, within the range that was stated.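

In this assay, among the compounds shown here, compound 4 gives 48100 nM, the only value in the set that is a number and not a limit, so the 2,4,6-trimethylphenyl group on this aromatic nitrogen gives a result that can be read. On these data alone, replacing 3-bromophenyl with 2,4,6-trimethylphenyl gives an at least 1.0-fold lower number from compound 3 to compound 4 (0.01 log units; that floor lies within the scatter); this is only a floor, and the true size of the step remains unknown. The other step in the set cannot be read, and most of the series still rests on a single limit: the limit of > 50000 nM in this assay, at which 3 of the 4 values shown sit.

As far as these compounds go, it remains open whether the numbered result belongs to the three methyl groups together or would persist with a single methyl group, an unsubstituted phenyl or a phenyl bearing a carboxylic acid or an amine at this position. From the compounds shown here alone, it also remains open whether 2,4,6-trimethylphenyl would give a number on the core of compound 1, and a clearer reading of this change would need a partner value that is not a limit.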